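The source may report more compounds than this note shows. Statements on the series, on what has been measured and on what is new or still open speak of the compounds shown alone.

Working notes on the series, read in an ADME assay on MRC5 cells (Homo sapiens) for cytotoxicity, read by fluorescence and resazurin assay, with a stated time of 3 days; on this read-out higher numbers stand for weaker inhibition and lower numbers for stronger inhibition. Compound 1 `Cc1cn(C2CCN(Cc3cccc(Oc4ccccc4)n3)CC2)c(=O)[nH]c1=O` gives > 64000 nM as a limit of the assay and not a number. Compound 2 `Cc1cn(C2CCN(Cc3cncc(Oc4cccc(Cl)c4)c3)CC2)c(=O)[nH]c1=O` gives > 64000 nM, also only a limit of the assay. These two compounds sit at the limit of > 64000 nM in this assay, at which 2 of the 3 values shown sit, so compound 2 has no number of its own. Among the compounds with values here, compound 3 `COc1ccc(Oc2cccc(CN3CCC(n4cc(C)c(=O)[nH]c4=O)CC3)c2)cc1` gives 28000 nM as the only actual number in the set.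

Compound 4 `Cc1cn(C2CCN(Cc3cncc(Oc4cc(Cl)cc(Cl)c4)c3)CC2)c(=O)[nH]c1=O` differs from compound 2 by chloro in place of hydrogen on an aromatic carbon and carries chloro in place of hydrogen on an aromatic carbon, taking 3-chlorophenoxy to 3,5-dichlorophenoxy. Within the data shown here, no measured step sizes this change. In this assay a small step towards stronger inhibition is expected, or none beyond the scatter. Compound 3 at 28000 nM shows that a number can be read in this set. A further limit reading remains quite possible. The estimated change is an at least 1.4-fold lower number from compound 2 to compound 4 (0.15 log units; that floor lies within the scatter) and rests on little data. The expected value for compound 4 is 45000 nM, with an estimated range of 20000 nM to 64000 nM.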

Compound 4, half-maximal inhibitory concentration: > 64000 nM
Compound 4: a limit, no number; the forecaster's own chance of this, stated with the estimate: 50%; middle value at least 1.4-fold (0.15 log units) away from the limit.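

Within the data shown here, compound 2 and compound 4 both stand only as limits of the assay, not numbers, and no step between them can be read. The compounds shown leave open whether taking 3-chlorophenoxy to 3,5-dichlorophenoxy changes the read-out at all, and by how much.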